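Liver-cell cytotoxicity notes on four related esters

The compounds below may be only part of what the source reports. "The series", "measured", "known", "first", "only" and "open" are said of these compounds alone.

Measured so far:
compound 1 `O=C(/C=C/c1ccccc1)Oc1ccc(-c2cc(=S)ss2)cc1`: 537000 nM
compound 2 `CC(C(=O)Oc1ccc(C(N)=S)cc1)c1ccc(C(=O)c2ccccc2)cc1`: 1180000 nM
compound 3 `NC(=S)c1ccc(OC(=O)/C=C/c2ccccc2)cc1`: > 800000 nM (a limit)

In an ADME assay on L02 cells (Homo sapiens) for cytotoxicity, read by MTT assay, with a stated time of 24 h (on this read-out higher numbers stand for weaker inhibition and lower numbers for stronger inhibition), compound 1 gives 537000 nM. In this assay compound 2 gives 1180000 nM, which sits beyond the scatter from the number for compound 1. For compound 3 this assay reports only a limit, > 800000 nM, not a number.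

Among the measured compounds shown here, the one counted change among the measured compounds runs from compound 3 to compound 1: a group of 6 heavy atoms (3 carbon, 3 sulfur; one five-membered aromatic ring with 2 hetero atoms) in place of a group of 3 heavy atoms (1 carbon, 1 nitrogen, 1 sulfur; no ring), on an aromatic carbon. The step is an at least 1.4-fold lower number from compound 3 to compound 1 (0.17 log units; that floor lies within the scatter). Its true size is open because the limit of > 800000 nM in this assay, at which 1 of the 3 values shown sits, fixes only a floor for the starting point. How the core of compound 2 differs from the core of compound 3 is not broken down here.

Compound 4 `CC(C(=O)Oc1ccc(-c2cc(=S)ss2)cc1)c1ccc(C(=O)c2ccccc2)cc1` is not yet measured. It stands to compound 2 as compound 1 stands to compound 3: a group of 6 heavy atoms (3 carbon, 3 sulfur; one five-membered aromatic ring with 2 hetero atoms) in place of a group of 3 heavy atoms (1 carbon, 1 nitrogen, 1 sulfur; no ring), on an aromatic carbon. The place is the same in both pairs, so this is the same change.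

For the measured compounds named here, the expectation for compound 4 rests on the measured pair: with an at least 1.4-fold lower number from compound 3 to compound 1 (0.17 log units; that floor lies within the scatter) as the only guide, the step from compound 2 to compound 4 is expected to be small, a 1.7-fold lower number from compound 2 to compound 4 (0.23 log units; within the scatter), and that floor itself lies within the scatter. The estimate for compound 4 in this assay is therefore 700000 nM, expected to fall between 350000 nM and 1400000 nM.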

Compound 4, half-maximal inhibitory concentration in the L02 assay: 544000 nM
Beside the measured number, compound 4's estimate is 1.3-fold (0.11 log units) above it; the measured number falls inside the stated range.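

In the L02 assay, putting the group of 6 heavy atoms in place of the group of 3 heavy atoms on the core of compound 2 gives a 2.2-fold lower number from compound 2 to compound 4 (0.34 log units; beyond the scatter), so this change again goes with a lower number on a second core. In a physicochemical assay for pharmacokinetics, read by spectrophotometry, in phosphate buffer, with a stated time of 5 min, tested at 40 uM, in the presence of a further agent that is not named here (a lower number here means that the compound disappears faster, a higher number that the compound lasts longer), compound 2 gives 0.163 h and compound 4 gives 0.0567 h. In the physicochemical assay, the same change gives a 2.9-fold lower number from compound 2 to compound 4 (0.46 log units; beyond the scatter), a read-out shown for this core alone. Set side by side, the two steps show the same direction but do not establish that the change carries over with the same size: the same change on two cores in the L02 assay, an at least 1.4-fold lower number (0.17 log units; that floor lies within the scatter) from compound 3 to compound 1 and a 2.2-fold lower number (0.34 log units; beyond the scatter) from compound 2 to compound 4; the limit leaves it open whether they differ. In the L02 assay, compound 3 stands at > 800000 nM, which is a limit and not a number, so the step on that core gives a floor and the comparison between the cores cannot be taken further.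

The compounds shown leave open whether the same direction would hold on cores beyond these two, and whether the shift in half-life and the shift in the cell read-out would go together in other pairs, as only one pair shows both. They also leave open what an amine, a carboxylic acid or a longer chain at the same aromatic carbon would do to either read-out.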